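The source may report more compounds than this note shows. Statements on the series, on what has been measured and on what is new or still open speak of the compounds shown alone.

Measured in a functional assay on ileum for inhibition of histamine H1 receptor (Cavia porcellus); on this read-out lower numbers stand for stronger inhibition and higher numbers for weaker inhibition:
compound 1 `CCNCCn1c(N2CCN(C)CC2)nc2ccccc21` gives 290 nM
compound 2 `C#CCOCCn1c(N2CCN(C)CC2)nc2ccccc21` gives 12 nM

Compound 2 holds the lower of the two numbers, the gap to compound 1 being beyond the scatter. Compound 3 `CCCCCCn1c(N2CCN(C)CC2)nc2ccccc21` is not yet measured; it differs from compound 2 by butyl in place of propargyloxy on a saturated chain carbon, two bonds along the chain from an aromatic nitrogen. Within the data shown here, the one measured step at this position, a 24-fold lower number from compound 1 to compound 2 (1.38 log units; beyond the scatter), shows that this part of the molecule moves this assay strongly, but it exchanges a different pair of groups and gives no direct guide for butyl. With no acceptor remaining in the chain, a moderate rise in this assay is expected, a 3.3-fold higher number from compound 2 to compound 3 (0.52 log units; beyond the scatter). Compound 3 is estimated at 40 nM, range 10 nM to 160 nM.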

Compound 3, half-maximal inhibitory concentration: 26 nM
Beside the measured number, compound 3's estimate is 1.5-fold (0.19 log units) above it; low and high end bracket the measured number.
By their numbers in this assay, from the lowest: compound 2; then compound 3; then compound 1.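

Butyl in place of propargyloxy gives a 2.2-fold higher number from compound 2 to compound 3 (0.34 log units; beyond the scatter) in this assay and shows that a low number at this position needs neither the oxygen nor the triple bond, although the step lies beyond the scatter. Butyl in place of ethylamino gives an 11-fold lower number from compound 1 to compound 3 (1.05 log units; beyond the scatter) and so retains most of the gain seen with propargyloxy, leaving compound 1 the highest of the three. No available evidence bears on the origin of either step. Open, as far as these compounds go, is whether propoxy, which has the oxygen without the triple bond, would match compound 2, and how a longer chain would read.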